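Aryl ketone variation on the shared core

The compounds below may be only part of what the source reports. "The series", "measured", "known", "first", "only" and "open" are said of these compounds alone.

The shared core is that of compound 1 `COc1ccc(-c2cc3ccccc3nc2C=O)cc1`. In a functional assay on MCF7 cells (Homo sapiens) for antiproliferative activity, read by XTT assay, with a stated time of 72 h (on this read-out higher numbers stand for weaker inhibition and lower numbers for stronger inhibition), compound 1 gives > 10000 nM, a limit of the assay rather than a number. Compound 2 `COc1ccc(-c2cc3ccccc3nc2/C=C/C(=O)c2ccc(O)cc2)cc1` gives 6710 nM in this assay. Compound 3 `COc1ccc(-c2cc3ccccc3nc2/C=C/C(=O)c2c(OC)cccc2OC)cc1` gives 4520 nM, and its number sits alongside that of compound 2, since the step of a 1.5-fold lower number from compound 2 to compound 3 (0.17 log units; within the scatter) lies within the scatter. Compound 4 `COc1ccc(-c2cc3ccccc3nc2/C=C/C(=O)c2cccs2)cc1` differs from compound 3 by thiophen-2-yl in place of 2,6-dimethoxyphenyl on a carbonyl carbon. Among the compounds with values here, the only measured step touching the aryl group on the carbonyl carbon is the one from compound 2 to compound 3, and it stayed within the scatter, so for compound 4 no step beyond the scatter is expected in either direction in this assay. Compound 4 is estimated at 5000 nM, range 2000 nM to 12000 nM, which means an expected step of a 1.1-fold higher number from compound 3 to compound 4 (0.04 log units; within the scatter).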

Compound 4, half-maximal inhibitory concentration: 1030 nM
The estimate for compound 4 lay 4.9-fold (0.69 log units) above the measured number; the whole stated range lies above it.
By their numbers in this assay, from the lowest: compound 4; then compounds 3 and 2 (each within the scatter of the next). At a limit, above all of these: compound 1.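

In this assay, within the data shown here, the aryl group on the carbonyl carbon does count: thiophen-2-yl gives a 4.4-fold lower number from compound 3 to compound 4 (0.64 log units; beyond the scatter) and a 6.5-fold lower number from compound 2 to compound 4 (0.81 log units; beyond the scatter) as the only steps beyond the scatter among the aryl changes, whereas 4-hydroxyphenyl and 2,6-dimethoxyphenyl had stayed within it. Formyl replaced by 2-((thiophen-2-yl)carbonyl)ethenyl gives an at least 9.7-fold lower number from compound 1 to compound 4 (0.98 log units; beyond the scatter) on the shared core, a step that starts from a limit and not a number: the limit of > 10000 nM in this assay, at which 1 of the 4 values shown sits.

Whether the gain is particular to thiophen-2-yl stays open, since furan-2-yl, unsubstituted phenyl and aminothiazolyl groups on the carbonyl carbon are not among the compounds shown.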